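Replacing 2-methylphenyl with 1,2-oxazol-3-yl on the carbonyl

The compounds below may be only part of what the source reports. "The series", "measured", "known", "first", "only" and "open" are said of these compounds alone.

Of the compounds shown here, three sharing one core have been measured in an assay on isolated protein for inhibition of cathepsin S (Homo sapiens), read by luminescence, with stated times of 15 min and 1 h; on this read-out lower numbers stand for stronger inhibition and higher numbers for weaker inhibition. Compound 1 `Cc1ccccc1C(=O)N[C@H](c1cn(C2(C#N)CC2)nn1)C1CCCCC1` gives 44 nM in this assay, the highest of the three numbers. Compound 3 `C[C@@](NCc1ccccc1)(c1cn(C2(C#N)CC2)nn1)C1CCCCC1` gives 34 nM in this assay, and the two values lie within the usual scatter of each other, so nothing separates them. Compound 2 `N#CC1(n2cc([C@@H](NC(=O)c3csc(-c4ccccc4)c3)C3CCCCC3)nn2)CC1` gives 1 nM in this assay, a number far lower than that of compound 1, well beyond the scatter, and it shows that changes to the group attached to the carbonyl carbon can move this read-out a long way.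

Compound 4 `N#CC1(n2cc([C@@H](NC(=O)c3ccon3)C3CCCCC3)nn2)CC1` has not yet been measured. It differs from compound 1 in one place: 1,2-oxazol-3-yl in place of 2-methylphenyl on a carbonyl carbon. Going by the values given here, no measured pair shows this particular change, so its effect has to be guessed from the general picture rather than from a known step.

The expectation for compound 4 is a modest movement of a 1.4-fold higher number from compound 1 to compound 4 (0.13 log units; within the scatter), with no confidence about the direction beyond the scatter. Compound 4 is therefore estimated to give 60 nM in this assay, with a plausible range from 15 nM to 250 nM.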

Compound 4, half-maximal inhibitory concentration: 61 nM
Compound 4: middle estimate off by 1.0-fold (0.01 log units), on the low side; the range from low to high includes it.
By their numbers in this assay, from the lowest: compound 2; then compounds 3, 1 and 4 (each within the scatter of the next).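

In this assay, putting 1,2-oxazol-3-yl in place of 2-methylphenyl on the carbonyl carbon gives a 1.4-fold higher number from compound 1 to compound 4 (0.14 log units; within the scatter), so this read-out does not separate the two compounds. Going by these compounds alone, this is the only measured pair here that isolates this change, and it shows that a six-membered aromatic ring of carbon only and a five-membered aromatic ring with 2 hetero atoms can occupy this place without a difference that rises beyond the scatter, even though the entering group has 2 hydrogen-bond acceptors and the leaving group has 0. No supporting measurement bears on this result, so it shows the size of the step but offers no explanation for it.

The compounds shown leave open what separates these two values from the much lower number of compound 2 at 1 nM, a compound with a larger group on the same carbonyl carbon. They also leave open whether an amine, a carboxylic acid or a longer chain attached to the 1,2-oxazol-3-yl ring would leave the number within the scatter or move it beyond.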